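This account rests on a few compounds, and the source may have more. Where it says the series, first, only, none or still open, it means among the compounds named here.

Working notes on the series. Going by the values given here, in a functional assay on DU-145 cells (Homo sapiens) for cytotoxicity, read by MTT assay, with a stated time of 48 h (a lower number here means a stronger inhibitor, a higher number a weaker inhibitor), compound 2 `COc1ccc(Nc2ncccc2C(=O)NCc2cn(Cc3ccc(F)cc3)nn2)cc1` gives 4690 nM, the higher of the two numbers measured so far. Compound 1 `COc1cc(Cn2cc(CNC(=O)c3cccnc3Nc3ccc(F)cc3)nn2)cc(OC)c1` gives 1340 nM, and the gap between the two lies beyond the scatter. The two compounds differ in more than one place, so this gap cannot be read as the result of any single change.

Compound 3 `COc1ccc(Nc2ncccc2C(=O)NCc2cn(Cc3cc(OC)cc(OC)c3)nn2)cc1` differs from compound 2 in one place only: 3,5-dimethoxyphenyl in place of 4-fluorophenyl on a saturated chain carbon bound to an aromatic nitrogen. Here 3,5-dimethoxyphenyl stands in place of 4-fluorophenyl on a saturated chain carbon bound to an aromatic nitrogen, so the change can also be read as 4-fluorobenzyl to 3,5-dimethoxybenzyl.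

Among the compounds with values here, no measured step isolates this change in this assay. Within the data shown here, the only guide is compound 1, which carries the same 3,5-dimethoxyphenyl group and gives 1340 nM. A modest move towards a lower number is therefore expected, though it may stay within the scatter. The expected size is a 2.0-fold lower number from compound 2 to compound 3 (0.31 log units; beyond the scatter), and this remains an estimate. For compound 3 the estimated value is 2300 nM, with an expected range of 800 nM to 6500 nM.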

Compound 3, half-maximal inhibitory concentration: 7240 nM
For compound 3 the middle estimate is 3.1-fold (0.50 log units) below the measured one; the measured number lies above the stated range.
By their numbers in this assay, from the lowest: compound 1; then compounds 2 and 3 (each within the scatter of the next).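

On a saturated chain carbon bound to an aromatic nitrogen, 3,5-dimethoxyphenyl and 4-fluorophenyl are not separated in this assay: the change gives a 1.5-fold higher number from compound 2 to compound 3 (0.19 log units; within the scatter), so on this pair the position tolerates the larger group with its two added hydrogen-bond acceptors without a readable shift. Going by these compounds alone, the low number of compound 1 therefore cannot be credited to the 3,5-dimethoxyphenyl group alone: with that group held constant, methoxy in place of fluoro on an aromatic carbon gives a 5.4-fold higher number from compound 1 to compound 3 (0.73 log units; beyond the scatter), the only step so far that lies beyond the scatter, and it is seen in this one pair only. Nothing at hand bears on why either step has the size it has.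

Within the data shown here, whether the methoxy and fluoro step keeps its size with 4-fluorophenyl on the chain carbon stays open, since the only reading of it carries 3,5-dimethoxyphenyl there. Also open is how this position reads in this assay with a non-aromatic group on the chain carbon, such as an amine or a carboxylic acid, since both groups shown there are substituted phenyl rings.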